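A few compounds are considered here, and "the series" means these few. Any claim that something is new, unique, unknown or untested is made for them only; others in the source may bear on it.

Of the compounds shown here, three with a shared amide linker have been measured in an assay on HeLa cells with Bile acid receptor (Homo sapiens) as the target, read by a luciferase reporter, with a stated time of 24 h; a lower number here means that less compound is needed, a higher number that more compound is needed for the effect. Compound 1, `CC(C)(C)c1ccc(C(=O)NCc2ccc(C(=O)O)cc2F)cc1`, gives 7.8 nM in this assay. Compound 2, `CC(C)(C)c1ccc(C(=O)NCc2ccc(-c3nnn[nH]3)cc2)cc1`, gives 120 nM in this assay. Compound 3, `O=C(O)c1ccc(CNC(=O)c2cccc(-c3ccccc3)c2)cc1`, gives 670 nM in this assay. Among these three numbers, compound 2 stands second highest: compound 3 is its nearest neighbour, with a number that sits beyond the usual scatter above it, and compound 1 is furthest from it, with a number that sits well below it.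

The next compound, compound 4, `CC(C)(C)c1ccc(C(=O)NCc2ccc(SC(F)(F)F)cc2)cc1`, has not yet been measured in this assay. It differs from compound 2 in one place: (trifluoromethyl)sulfanyl in place of 1H-tetrazol-5-yl on an aromatic carbon. In words, a (trifluoromethyl)sulfanyl takes the place of a 1H-tetrazol-5-yl on an aromatic carbon, para to a large group.

Going by the values given here, no measured pair shows this particular change, so the size of the step is uncertain. The expectation is that compound 4 will need more compound than compound 2, and the step from compound 2 to compound 4 is estimated at a 13-fold higher number from compound 2 to compound 4 (1.10 log units; beyond the scatter). Compound 4 is therefore expected to give about 1500 nM in this assay, with a likely range from 300 nM to 8000 nM.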

Compound 4, half-maximal effective concentration: 0.4 nM
For compound 4 the middle estimate is 3800-fold (3.57 log units) above the measured one; the whole stated range lies above it.
By their numbers in this assay, from the lowest: compound 4; then compound 1; then compound 2; then compound 3.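

In this assay, the step from the 1H-tetrazol-5-yl group to the (trifluoromethyl)sulfanyl group is a 300-fold lower number from compound 2 to compound 4 (2.48 log units; beyond the scatter), a large change from a single swap on an aromatic carbon, para to a large group. Both groups have the same count of heavy atoms, so this position can respond strongly to which atoms are present, even when the count stays the same. The new group has no ring and 0 hydrogen-bond donors, showing that neither a ring nor a hydrogen-bond donor at this position is required for a low number in this assay, although no available evidence explains the size of the step.

The ring, the hydrogen-bond donor and the atom types all change together in this one swap, leaving it unclear which of these differences matters most. A nitrile, a methoxy group or a chlorine atom at the same position, on the same core, would help show whether the low number is specific to (trifluoromethyl)sulfanyl or is shared by other small groups without a ring.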